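Working notes: from compound 3 to compound 4

The source may hold more compounds than are shown below. What is called first, only, known or untested is meant among the compounds shown, and "the series" means these compounds.

Three compounds have numbers in a functional assay on A549 cells (Homo sapiens) for antiproliferative activity, read by sulforhodamine B assay, with a stated time of 48 h; on this read-out lower numbers stand for stronger inhibition and higher numbers for weaker inhibition. Compound 1 `COc1ccc(C(=O)/C=C/c2ccccc2-c2ccc(F)cc2)cc1OC` gives 7500 nM, compound 2 `COc1ccc(C(=O)/C=C/c2ccccc2-c2ccc(F)nc2)cc1OC` gives 17000 nM, and compound 3 `COc1cc(C(=O)/C=C/c2ccccc2-c2ccc(F)cc2)ccc1O` gives 4600 nM. Compound 3 and compound 1 share the low end of this small set, as a 1.6-fold lower number from compound 1 to compound 3 (0.21 log units; within the scatter) lies within the scatter, while compound 2 stands clearly above both.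

Compound 4 `COc1cc(C(=O)/C=C/c2ccccc2-c2ccc(F)nc2)ccc1O` differs from compound 3 in one place: 6-fluoropyridin-3-yl in place of 4-fluorophenyl on an aromatic carbon. This puts 6-fluoropyridin-3-yl in place of 4-fluorophenyl on an aromatic carbon.

The same exchange has been measured once, as a 2.3-fold higher number from compound 1 to compound 2 (0.36 log units; beyond the scatter), a modest step beyond the scatter. For the measured compounds named here, this single pair is the only direct evidence, and the data do not show that the step carries over unchanged to compound 3. A modest move toward a higher number is therefore expected in this assay, with an expected step of a 2.2-fold higher number from compound 3 to compound 4 (0.34 log units; beyond the scatter). For compound 4 the estimate is 10000 nM, with an expected range of 5000 nM to 21000 nM.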

Compound 4, half-maximal inhibitory concentration: 13000 nM
Compound 4: middle estimate off by 1.3-fold (0.11 log units), on the low side; low and high end bracket the measured number.
By their numbers in this assay, from the lowest: compounds 3, 1, 4 and 2 (each within the scatter of the next, the first and the last beyond it).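

In this assay, the exchange of 4-fluorophenyl for 6-fluoropyridin-3-yl now has a second measurement, a 2.8-fold higher number from compound 3 to compound 4 (0.45 log units; beyond the scatter), and it keeps its direction on a second core, with a size that matches the first: the same change on two cores in this assay, a 2.3-fold higher number (0.36 log units; beyond the scatter) from compound 1 to compound 2 and a 2.8-fold higher number (0.45 log units; beyond the scatter) from compound 3 to compound 4, 1.2-fold (0.10 log units) apart, within the scatter of two such steps. Hydrogen in place of methyl on the oxygen likewise reads the same with either group present, here a 1.3-fold lower number from compound 2 to compound 4 (0.12 log units; within the scatter): the same change on two cores in this assay, a 1.6-fold lower number (0.21 log units; within the scatter) from compound 1 to compound 3 and a 1.3-fold lower number (0.12 log units; within the scatter) from compound 2 to compound 4, 1.2-fold (0.10 log units) apart, within the scatter of two such steps. Across these four compounds the two changes therefore behave as separate steps, and only the ring exchange moves the number beyond the scatter.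

The compounds shown carry only these two groups on this aromatic carbon, so the result says nothing about other groups there. As far as these compounds go, what an amine or a carboxylic acid in place of the fluorine would do in this assay remains open.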